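Ring swap on the sulfur of the acetamide side chain

The source may hold more compounds than are shown below. What is called first, only, known or untested is meant among the compounds shown, and "the series" means these compounds.

The three measured compounds share one core and differ only in the ring on the sulfur. Compound 1 `Cn1c(-c2ccc(NC(=O)CSc3nc4ccccc4s3)cc2)nc(-c2ccccc2)c1-c1ccccc1` carries 1,3-benzothiazol-2-yl and gives 59% in a functional assay on MCF7 cells (Homo sapiens) for cytotoxicity, read by MTT assay, with a stated time of 24 h, tested at 32 ug/mL; a higher number here means a stronger effect of the compound at the concentration tested, a lower number a weaker effect. Compound 2 `Cn1cnnc1SCC(=O)Nc1ccc(-c2nc(-c3ccccc3)c(-c3ccccc3)n2C)cc1` carries 4-methyl-4H-1,2,4-triazol-3-yl, and in this assay compound 2 gives 89.2%. Compound 3 `Cn1nnnc1SCC(=O)Nc1ccc(-c2nc(-c3ccccc3)c(-c3ccccc3)n2C)cc1` carries 1-methyl-1H-tetrazol-5-yl; in this assay compound 3 gives 77.5%, the second highest of the three numbers: a number 11.7 percentage points lower from compound 2 to compound 3 (beyond the scatter), whereas a number 18.5 percentage points higher from compound 1 to compound 3 (beyond the scatter).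

The next step leads to compound 4 `Cn1ccnc1SCC(=O)Nc1ccc(-c2nc(-c3ccccc3)c(-c3ccccc3)n2C)cc1`: 1-methyl-1H-imidazol-2-yl in place of 1-methyl-1H-tetrazol-5-yl on a sulfur. All three measured steps concern this same place on the sulfur. a number 30.2 percentage points higher from compound 1 to compound 2 (beyond the scatter) and a number 18.5 percentage points higher from compound 1 to compound 3 (beyond the scatter) set both 4-methyl-4H-1,2,4-triazol-3-yl and 1-methyl-1H-tetrazol-5-yl well above 1,3-benzothiazol-2-yl, while the gap between those two is only modest, a number 11.7 percentage points lower from compound 2 to compound 3 (beyond the scatter). Among the measured compounds shown here, no measured pair separates a ring with four hetero atoms from one with two, so the direction for compound 4 cannot be read off the data. A modest step at most is expected, probably within the scatter, a number 2.5 percentage points higher from compound 3 to compound 4 (within the scatter). Compound 4 is therefore estimated at 80% in this assay, with a range from 62% to 94%.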

Compound 4, a percentage reported as activity, at one concentration (the size of the read-out at that concentration, not a potency): 43.4%
Compound 4: the middle estimate sits 36.6 percentage points above what was measured; the measured number lies below the stated range.
By their numbers in this assay, from the lowest: compound 4; then compound 1; then compound 3; then compound 2.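

This position is more sensitive than the first three compounds showed: with the heavy-atom count unchanged, 1-methyl-1H-imidazol-2-yl in place of 1-methyl-1H-tetrazol-5-yl on the sulfur gives a large step (a number 34.1 percentage points lower from compound 3 to compound 4 (beyond the scatter)), and the distance from the top of the series is larger still (a number 45.8 percentage points lower from compound 2 to compound 4 (beyond the scatter)). A small methylated five-membered ring is therefore not enough to hold the number, since compound 4 also falls under the fused ring (a number 15.6 percentage points lower from compound 1 to compound 4 (beyond the scatter)) and is now the lowest of the four, while a rule of more hetero atoms giving a higher number fits compound 3 and compound 4 but has compound 2 against it (a number 11.7 percentage points lower from compound 2 to compound 3 (beyond the scatter)). Nothing available explains these steps.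

Open, going by these compounds, is whether the methyl on these rings contributes, and whether an open chain ending in an amine or a carboxylic acid on the sulfur could replace the ring. On these data alone, all four numbers are read-outs at one concentration, so how the order would look as potency remains unknown.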